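Thiophen-2-yl to Thiophen-3-yl: Weighing a Small Change

The compounds below may be only part of what the source reports. "The series", "measured", "known", "first", "only" and "open" are said of these compounds alone.

Compound 1 `O=C(/C=C/c1cccs1)c1cc(O)c(O)c([N+](=O)[O-])c1` was tested in an assay for inhibition of Catechol O-methyltransferase (Rattus norvegicus), read by fluorescence and spectrophotometry (on this read-out lower numbers stand for stronger inhibition and higher numbers for weaker inhibition), and gave 190 nM. Compound 2 `CC(=O)N1N=C(c2cc(O)c(O)c([N+](=O)[O-])c2)CC1c1cccs1` gives 210 nM, a number within the scatter of compound 1, so no order can be read between them; compound 3 `CC(=O)N1N=C(c2cc(O)c(O)c([N+](=O)[O-])c2)CC1c1ccc(C#N)cc1` gives 48 nM, a lower number beyond the scatter. Compound 1 thus holds the second highest of the three numbers. Compound 4 `O=C(/C=C/c1ccsc1)c1cc(O)c(O)c([N+](=O)[O-])c1` is not yet measured; it differs from compound 1 by thiophen-3-yl in place of thiophen-2-yl on a double-bonded chain carbon bound to a double-bonded chain carbon. Among the measured compounds shown here, the one measured step, a 4.4-fold lower number from compound 2 to compound 3 (0.64 log units; beyond the scatter), concerns a different change at a saturated ring carbon rather than a double-bonded chain carbon, so it offers little direct guidance. For two groups with the same atoms joined differently, no step beyond the scatter is expected. Compound 4 is therefore expected to give 190 nM (range 90 nM to 400 nM), a step of no change at the digits printed from compound 1 to compound 4 (within the scatter).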

Compound 4, half-maximal inhibitory concentration: 230 nM
Compound 4: middle estimate off by 1.2-fold (0.08 log units), on the low side; measured number inside the range.
By their numbers in this assay, from the lowest: compound 3; then compounds 1, 2 and 4 (each within the scatter of the next).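

Moving the attachment point from thiophen-2-yl to thiophen-3-yl gives a 1.2-fold higher number from compound 1 to compound 4 (0.08 log units; within the scatter) in this assay, so this read-out does not separate the two groups at this chain carbon. This is the first step shown at this position, since the earlier step concerned a saturated ring carbon. No measurement here bears on why the two groups match. Still open, from the compounds shown here alone, is whether a group with different atoms at this chain carbon, such as furan-2-yl or an amine, would move the number beyond the scatter. Thiophen-3-yl on the saturated ring carbon of compound 2 also remains an open case.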